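Chloro for fluoro on two cores, one step known

A few compounds are considered here, and "the series" means these few. Any claim that something is new, unique, unknown or untested is made for them only; others in the source may bear on it.

Compound 1 `Nc1ccccc1NC(=O)c1ccc(CNC(=O)c2n[nH]cc2NC(=O)c2c(F)cccc2Cl)cc1` and compound 2 `Nc1ccccc1NC(=O)c1ccc(CNC(=O)c2n[nH]cc2NC(=O)c2c(Cl)cccc2Cl)cc1` share one core; compound 3 `O=C(NO)c1ccc(CNC(=O)c2n[nH]cc2NC(=O)c2ccccc2F)cc1` and compound 4 `O=C(NO)c1ccc(CNC(=O)c2n[nH]cc2NC(=O)c2ccccc2Cl)cc1` share another. The difference between the two cores is not broken down here. In a functional assay on HCT-116 cells (Homo sapiens) for inhibition, read by CCK-8 assay, with a stated time of 72 h (a higher number here means a weaker inhibitor, a lower number a stronger inhibitor), compound 1 gives 700 nM and compound 2 gives 710 nM. The change between them, (chloro in place of fluoro on an aromatic carbon), made a 1.0-fold higher number from compound 1 to compound 2 (0.01 log units; within the scatter). Compound 3 gives 2200 nM in this assay, the highest of the three numbers and beyond the scatter from both compound 1 and compound 2. Compound 4 has not been measured in this assay. It differs from compound 3 by chloro in place of fluoro on an aromatic carbon, the same kind of change as from compound 1 to compound 2; the surroundings differ in that the carbon in compound 1 is also meta to a chloro group (1 heavy atom), while in compound 3 it is only ortho to a large group. Among the compounds with values here, the expectation for compound 4 rests on the single earlier instance: from compound 1 to compound 2 the change gave a 1.0-fold higher number from compound 1 to compound 2 (0.01 log units; within the scatter), a step within the scatter, so the step to compound 4 is expected to be no change at the digits printed from compound 3 to compound 4 (within the scatter), again within the scatter. Because compound 3 gives 2200 nM, compound 4 is estimated at 2200 nM, with a range from 1000 nM to 4800 nM. One instance on another core is a thin basis, so the range is kept wide.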

Compound 4, half-maximal inhibitory concentration: 2400 nM
The estimate for compound 4 lay 1.1-fold (0.04 log units) below the measured number; the range from low to high includes it.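

In this assay, chloro in place of fluoro on an aromatic carbon of the core of compound 3 gave a 1.1-fold higher number from compound 3 to compound 4 (0.04 log units; within the scatter), so this swap, placed on the ring as 2-fluorophenyl to 2-chlorophenyl, leaves the read-out within the scatter. Set beside the earlier step, the change reads alike on the two cores: the same change on two cores in this assay, a 1.0-fold higher number (0.01 log units; within the scatter) from compound 1 to compound 2 and a 1.1-fold higher number (0.04 log units; within the scatter) from compound 3 to compound 4, 1.1-fold (0.03 log units) apart, within the scatter of two such steps. This supports carrying the swap between these two cores as a change of no visible consequence in this assay, but it rests on two pairs, whose rings also differ in that compound 1 and compound 2 carry a second halogen while compound 3 and compound 4 carry none, and it says nothing about any other change, about why the numbers stay level, or about what separates the two cores.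

The compounds shown leave open whether a group other than these two halogens, such as methoxy, trifluoromethyl or nitrile, would move the number in this assay when set in the same place on either core. Also open, on these data alone, is whether the match between the two steps would hold on a third core or in another cell line.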